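The compounds below may be only part of what the source reports. "The series", "measured", "known", "first", "only" and "open" are said of these compounds alone.

Measured compounds:
- compound 1 `CC(=O)c1cc(-c2ccccc2)cc2cc(-c3ccccc3)[nH]c12` gives 65.8% in a functional assay on MCF7 cells (Homo sapiens) for cytotoxicity, read by MTT assay, with a stated time of 2 days, tested at 100 uM; on this read-out higher numbers stand for a weaker effect at the one concentration tested and lower numbers for a stronger effect
- compound 2 `CC(=O)c1cc(-c2ccccc2)cc2cc(-c3ccc(F)cc3)[nH]c12` gives 73.3% in this assay
- compound 3 `COc1ccc(-c2cc3cc(-c4ccccc4)cc(C(C)=O)c3[nH]2)cc1` gives 43.5% in this assay

Among these three, compound 1 stands second highest. Its nearest neighbour is compound 2, reached by a number 7.5 percentage points higher from compound 1 to compound 2 (within the scatter), a fluoro in place of hydrogen on an aromatic carbon, so the two are not separated. Its furthest neighbour is compound 3, reached by a number 22.3 percentage points lower from compound 1 to compound 3 (beyond the scatter), a methoxy in place of hydrogen on an aromatic carbon. The remaining step, a number 29.8 percentage points lower from compound 2 to compound 3 (beyond the scatter), is likewise modest.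

Compound 4 `CC(=O)c1cc(/C=C/c2ccccc2)cc2cc(-c3ccccc3)[nH]c12` differs from compound 1 in another way: 2-phenylethenyl in place of phenyl on an aromatic carbon. Among the compounds with values here, none of the measured steps touches this place; all three alter the phenyl on the other ring, and they give no guide to what lengthening the substituent at this carbon by a double bond does. The only direct anchor is the value of compound 1 itself. With nothing pointing one way, no change beyond the scatter is expected, though a step as large as the modest ones already seen cannot be ruled out in either direction. For compound 4 the estimate is therefore 62%, between 42% and 82%, meaning an expected step of a number 3.8 percentage points lower from compound 1 to compound 4 (within the scatter).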

Compound 4, a percentage reported as activity, at one concentration (the size of the read-out at that concentration, not a potency): 34.1%
Beside the measured number, compound 4's estimate is 27.9 percentage points above it; the measured number lies below the stated range.
By their numbers in this assay, from the lowest: compounds 4 and 3 (each within the scatter of the next); then compounds 1 and 2 (each within the scatter of the next).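

In this assay, the aromatic carbon meta to the acetyl group turns out to be a sensitive place: putting 2-phenylethenyl in place of phenyl gives a number 31.7 percentage points lower from compound 1 to compound 4 (beyond the scatter), a large step. The earlier steps shown here all altered the phenyl on the other ring and were modest at most, so they did not show that this second place can also move the read-out, here towards a stronger effect at the one concentration tested. The entering group keeps the single aromatic ring of carbon and adds one double bond outside aromatic rings, but nothing shown bears on the origin of this step.

The compounds shown leave open whether the double bond itself matters, which 2-phenylethyl at this carbon would address, and whether a shorter group such as ethenyl or a polar one such as an amine or a carboxylic acid would behave in the same way. Also open, from the compounds shown here alone, is whether 2-phenylethenyl at this carbon and methoxy on the other phenyl would add up when they are combined in one compound.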